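Sulfonamide to chlorobenzamide in a fluorophenyl imidazothiazole series

This account rests on a few compounds, and the source may have more. Where it says the series, first, only, none or still open, it means among the compounds named here.

Measured compounds in a functional assay on SK-MEL-28 cells (Homo sapiens) for cytotoxicity, read by MTT assay; on this read-out lower numbers stand for stronger inhibition and higher numbers for weaker inhibition:
compound 1, `O=S(=O)(NCCNc1nccc(-c2c(-c3cccc(F)c3)nc3sccn23)n1)c1ccc(F)cc1`, gives 9450 nM
compound 2, `O=S(=O)(NCCNc1nccc(-c2c(-c3cccc(F)c3)nc3sccn23)n1)c1ccc(Cl)cc1`, gives 18600 nM
compound 3, `Cc1ccc(S(=O)(=O)NCCNc2nccc(-c3c(-c4cccc(F)c4)nc4sccn34)n2)cc1`, gives > 20000 nM

Compound 3 stands at the weak end of the set: its value is not a number but a limit of the assay, (the limit of > 20000 nM in this assay, at which 1 of the 3 values shown sits). The step of an at least 2.1-fold higher number from compound 1 to compound 3 (0.32 log units; beyond the scatter) is therefore known only as a floor, and the step of an at least 1.0-fold higher number from compound 2 to compound 3 (0.03 log units; that floor lies within the scatter) likewise. Among the compounds with values here, the one fully numbered step, a 2.0-fold higher number from compound 1 to compound 2 (0.29 log units; within the scatter), shows that exchanging the halogen on the terminal ring hardly moves the read-out.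

Compound 4, `O=C(NCCCNc1nccc(-c2c(-c3cccc(F)c3)nc3sccn23)n1)c1ccc(Cl)cc1`, arises from compound 3 by the change ((((4-chlorophenyl)carbonyl)amino)methyl in place of ((4-methylphenyl)sulfonyl)amino on a saturated chain carbon, two bonds along the chain from a nitrogen on an aromatic ring). Within the data shown here, this alters both the linking group and the chain length, and none of the measured steps addresses either of those changes; the three measured compounds differ only at one ring substituent. What can be drawn from them is that compound 2, which carries the same chloro-substituted ring, sits near the upper part of the range, and that the whole set is weakly active in this assay.

Compound 4 is therefore expected to remain weak, with the step of an at least 1.2-fold lower number from compound 3 to compound 4 (0.09 log units; that floor lies within the scatter) of uncertain direction, and its value is estimated at 16000 nM, within 5000 nM to 40000 nM.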

Compound 4, half-maximal inhibitory concentration: > 20000 nM
Compound 4 ended at the assay's limit; the forecaster's own chance of this, stated with the estimate: 40%; at least 1.2-fold (0.09 log units) between middle value and limit.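

In this assay compound 4 gives > 20000 nM, which is a limit and not a number, so the step between compound 3 and compound 4 cannot be read. On the saturated chain carbon, (((4-chlorophenyl)carbonyl)amino)methyl in place of ((4-chlorophenyl)sulfonyl)amino gives an at least 1.0-fold higher number from compound 2 to compound 4 (0.03 log units; that floor lies within the scatter), and the same group in place of ((4-fluorophenyl)sulfonyl)amino gives an at least 2.1-fold higher number from compound 1 to compound 4 (0.32 log units; beyond the scatter). The earlier compounds differed only at one ring substituent, whereas this result shows that a change in the linking group and chain together brings no measurable gain in this assay, and compounds with either linking group now stand at the same limit: the limit of > 20000 nM in this assay, at which 2 of the 4 values shown sit.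

The compounds shown leave open whether the carbonyl link or the added methylene accounts for the result, since a carbonyl-linked compound on the shorter chain or a sulfonyl-linked compound on the longer one would be needed to separate the two. They also leave open how a terminal amine or a carboxylic acid in place of the 4-chlorophenyl ring would read out at this position.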